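The compounds below may be only part of what the source reports. "The series", "measured", "known", "first", "only" and "open" are said of these compounds alone.

Three compounds here share one core. Compound 1 `Cn1nc(-c2ccnc(Nc3ccc(Cl)cc3)n2)c2ccccc21` gives 8730 nM in a functional assay on HCT-116 cells (Homo sapiens) for antiproliferative activity, read by MTT assay, with a stated time of 72 h; on this read-out lower numbers stand for stronger inhibition of growth and higher numbers for weaker inhibition of growth. Compound 2 `Cn1nc(-c2ccnc(Nc3cccc(Cl)c3)n2)c2ccccc21` differs from compound 1 by 3-chlorophenyl in place of 4-chlorophenyl on a nitrogen on an aromatic ring, and in this assay compound 2 gives 6400 nM, a step of a 1.4-fold lower number from compound 1 to compound 2 (0.13 log units; within the scatter). Compound 3 `Cn1nc(-c2ccnc(Nc3ccc([N+](=O)[O-])cc3)n2)c2ccccc21` differs from compound 1 by nitro in place of chloro on an aromatic carbon, and in this assay compound 3 gives 8220 nM, a step of a 1.1-fold lower number from compound 1 to compound 3 (0.03 log units; within the scatter). Compound 4 `Cn1nc(-c2ccnc(Nc3cccc([N+](=O)[O-])c3)n2)c2ccccc21` has not been measured; it differs from compound 2 by nitro in place of chloro on an aromatic carbon. This is the same kind of change as that from compound 1 to compound 3, but there the new group sits para to a large group, whereas here it sits meta to a large group. Because the step of a 1.1-fold lower number from compound 1 to compound 3 (0.03 log units; within the scatter) stayed within the scatter, a similarly small step is expected here, a 1.1-fold lower number from compound 2 to compound 4 (0.03 log units; within the scatter). Compound 4 is therefore expected to give about 6000 nM in this assay, most likely between 3000 nM and 12000 nM.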

Compound 4, concentration for 50% growth inhibition: 490 nM
Compound 4: the middle estimate sits 12-fold (1.09 log units) above what was measured; the measured number lies below the stated range.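

In this assay, nitro in place of chloro gives a 13-fold lower number from compound 2 to compound 4 (1.12 log units; beyond the scatter), so this change does not keep one size from one core to another in this series: the same change on two cores in this assay, a 1.1-fold lower number (0.03 log units; within the scatter) from compound 1 to compound 3 and a 13-fold lower number (1.12 log units; beyond the scatter) from compound 2 to compound 4, 12-fold (1.09 log units) apart, beyond the scatter of two such steps. The size of the step at one place therefore cannot be relied on to predict its size at the other. This does not show why the two steps differ, and two pairs of compounds give no general rule for other compounds.

The compounds shown leave open whether other groups, such as a nitrile, an amine or a carboxylic acid, would also give a large step when meta to a large group. They also leave open whether the step seen for nitro would appear in other cell lines.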